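A few compounds are considered here, and "the series" means these few. Any claim that something is new, unique, unknown or untested is made for them only; others in the source may bear on it.

Compound 1 `CC(=O)N(C)C(C)C#CCn1ccnc1`, compound 2 `CC(=O)N(C)C(C)C#CCn1ccnc1C` and compound 3 `O=C1NCCN1CC#CCn1ccnc1` have been measured.

In a functional assay on the whole organism for antagonist activity, with Mus musculus as the target (a higher number here means that more compound is needed for the effect, a lower number that less compound is needed), compound 1 gives > 100 mg/kg, which is a limit of the assay and not a number. Compound 2 gives 11.8 mg/kg in this assay. Compound 3 gives > 100 mg/kg in this assay, again a limit rather than a number. Two of the three values therefore rest at the limit of > 100 mg/kg in this assay, at which 2 of the 3 values shown sit.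

Compound 1 and compound 2 differ in one place: methyl in place of hydrogen on an aromatic carbon. This change produced an at least 8.4-fold lower number from compound 1 to compound 2 (0.92 log units; beyond the scatter). Compound 4 `Cc1cncn1CC#CCN1CCNC1=O` has not yet been measured in this assay. It arises from compound 3 by methyl in place of hydrogen on an aromatic carbon. Among the measured compounds shown here, that is the same kind of change as the one from compound 1 to compound 2, but not the same: in compound 2 the methyl sits between two ring nitrogen atoms, whereas in compound 4 it is next to the ring nitrogen, two ring bonds from the ring nitrogen. The difference between the core of compound 1 and the core of compound 3 is not broken down here. Because the same kind of change produced an at least 8.4-fold lower number from compound 1 to compound 2 (0.92 log units; beyond the scatter), for compound 4 a step of an at least 2.0-fold lower number from compound 3 to compound 4 (0.30 log units; that floor lies within the scatter) is expected, though the changed place and the different core make this less certain. For compound 4 a value of 50 mg/kg is estimated, with a likely range from 10 mg/kg to 200 mg/kg.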

Compound 4, dose for half-maximal effect: > 100 mg/kg
Compound 4: only a limit was reported; the forecaster's own chance of this, stated with the estimate: 45%; middle value at least 2.0-fold (0.30 log units) from the limit.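

In this assay compound 3 and compound 4 both rest at a limit and not at a number, so no step between them can be read: the limit of > 100 mg/kg in this assay, at which 3 of the 4 values shown sit.

The compounds shown leave open whether methyl in place of hydrogen on an aromatic carbon lowers the number at all on the core of compound 3.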